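Methyl in place of fluoro on compound 2

This account rests on a few compounds, and the source may have more. Where it says the series, first, only, none or still open, it means among the compounds named here.

In a functional assay on PC-3 cells (Homo sapiens) for cytotoxicity, read by sulforhodamine B assay, with a stated time of 48 h (a lower number here means a stronger inhibitor, a higher number a weaker inhibitor), compound 1 (`C=CCOc1ccc(F)cc1C(=O)c1cccnc1`) shows > 100000 nM as a limit, not a number. Compound 3 (`C=CCOc1ccc(Br)cc1C(=O)c1cccnc1`) gives 59000 nM in the same test. For the measured compounds named here, compound 2 (`O=C(c1cccnc1)c1cc(F)ccc1O`) gives 11800 nM as the lowest number so far. Compound 4 (`Cc1ccc(O)c(C(=O)c2cccnc2)c1`) differs from compound 2 by methyl in place of fluoro on an aromatic carbon para to a hydroxy group. The closest measured change is bromo in place of fluoro, and the step of an at least 1.6-fold lower number from compound 1 to compound 3 (0.22 log units; that floor lies within the scatter) has a floor within the scatter. Hydrogen in place of allyl on an oxygen gave the step of an at least 8.4-fold lower number from compound 1 to compound 2 (0.92 log units; beyond the scatter) beyond the scatter, but at another place. No step beyond the scatter is therefore expected in this assay for this exchange. The estimated step is a 1.2-fold lower number from compound 2 to compound 4 (0.07 log units; within the scatter) and stays within the scatter. Compound 4 is expected at 10000 nM with an estimated range of 4000 nM to 30000 nM around that value.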

Compound 4, half-maximal inhibitory concentration: 10000 nM
For compound 4 middle estimate and measured number coincide at the digits printed; low and high end bracket the measured number.
By their numbers in this assay, from the lowest: compounds 4 and 2 (each within the scatter of the next); then compound 3. At a limit, above all of these: compound 1.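

In this assay methyl and fluoro cannot be told apart on this aromatic carbon para to a hydroxy group, with a 1.2-fold lower number from compound 2 to compound 4 (0.07 log units; within the scatter) as the step. The earlier exchange on this carbon, bromo in place of fluoro, gave only a floor on the allyl ethers, whereas this step is read between two numbers with the hydroxy group free. Nothing shown here accounts for the two groups reading alike.

As far as these compounds go, whether an amine or a carboxylic acid on this carbon would also leave the number in this range stays open. So does whether bromo matches fluoro once the allyl group gives way to hydrogen.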